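The compounds below may be only part of what the source reports. "The series", "measured", "known", "first", "only" and "open" are said of these compounds alone.

Within the data shown here, compound 2, `O=C1/C(=C/c2ccccc2Cl)CCCc2ccccc21`, is one of two compounds measured in a functional assay on P388 cells (Mus musculus) for inhibition; a higher number here means a weaker inhibitor, a lower number a stronger inhibitor. In this assay compound 2 gives 12700 nM. Among the measured compounds shown here, its only measured neighbour is compound 1, `O=C1/C(=C/c2ccccc2Br)CCCc2ccccc21`, which carries a bromo group where compound 2 carries a chloro group; in this assay compound 1 gives 19800 nM. The move a 1.6-fold lower number from compound 1 to compound 2 (0.19 log units; within the scatter) is a step within the scatter, so the two compounds cannot be set apart on these numbers, and compound 2 stands beside compound 1 rather than ahead of it.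

Compound 3, `COc1ccccc1/C=C1\CCCc2ccccc2C1=O`, has not yet been measured. It differs from compound 2 by methoxy in place of chloro on an aromatic carbon. For the measured compounds named here, the only measured step that bears on this position is a 1.6-fold lower number from compound 1 to compound 2 (0.19 log units; within the scatter), which was within the scatter, and it concerns an exchange of one halogen for another, not the entry of a methoxy group. On that thin basis, the step of a 1.1-fold higher number from compound 2 to compound 3 (0.04 log units; within the scatter) is expected to stay within the scatter, with no clear direction. Compound 3 is therefore estimated to give 14000 nM in this assay, within a range from 5000 nM to 40000 nM.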

Compound 3, half-maximal inhibitory concentration: 18000 nM
Compound 3: the middle estimate sits 1.3-fold (0.11 log units) below what was measured; low and high end bracket the measured number.
By their numbers in this assay, from the lowest: compounds 2, 3 and 1 (each within the scatter of the next).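

The move a 1.4-fold higher number from compound 2 to compound 3 (0.15 log units; within the scatter) and the move a 1.1-fold lower number from compound 1 to compound 3 (0.04 log units; within the scatter) show that, on this aromatic carbon ortho to a large group, methoxy can stand in place of either halogen without a step beyond the scatter. The earlier compounds shown here showed only one halogen exchanged for another, whereas this change brings in a group of a different make-up: methoxy has 2 heavy atoms, carbon and oxygen, and 1 hydrogen-bond acceptor, where chloro has 1 heavy atom and 0 hydrogen-bond acceptors. Compound 1, compound 2 and compound 3 therefore cannot be set apart in this assay, and nothing available here accounts for how close their numbers lie.

On these data alone, what stays open is whether any group at this position can produce a step beyond the scatter, for instance an amine, a carboxylic acid or a longer chain such as ethoxy. Also open, as far as these compounds go, is whether methoxy and the two halogens would stay this close on the same core in a different setting, since all three compounds are compared here in this one assay alone.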